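Dropping a phenyl from compound 2: expected cytotoxicity

The source may hold more compounds than are shown below. What is called first, only, known or untested is meant among the compounds shown, and "the series" means these compounds.

Compound 2 `CCC(C)C(NC(=O)n1nnc2ccccc21)C(=O)NC(c1ccccc1)c1ccccc1` stands alone with a real number: in a functional assay on HEL cells (Homo sapiens) for cytotoxicity (a higher number here means that more compound is tolerated, a lower number that less compound is tolerated), compound 2 gives 80 ug/mL. Compound 1 `CCC(C)C1NC(=O)N(C2CCCC2)C1=O` is the only other entry, and in this assay compound 1 reaches only a limit of the assay, > 100 ug/mL, as the limit of > 100 ug/mL in this assay, at which 1 of the 2 values shown sits, records. Compound 3 `CCC(C)C(NC(=O)n1nnc2ccccc21)C(=O)NCc1ccccc1` differs from compound 2 by hydrogen in place of phenyl on a saturated chain carbon bound to an amide-type nitrogen and an aromatic carbon. Going by the values given here, no measured pair shows what such a change does here. The step of a 1.3-fold higher number from compound 2 to compound 3 (0.10 log units; within the scatter) is expected to be small, toward more compound tolerated, perhaps within the scatter. Compound 3 is estimated at 100 ug/mL, between 50 ug/mL and 200 ug/mL, with a fair chance of only a limit being reported.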

Compound 3, minimum cytotoxic concentration: 200 ug/mL
Beside the measured number, compound 3's estimate is 2.0-fold (0.30 log units) below it, and the stated range covers the measured number.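

In this assay, hydrogen in place of phenyl on a saturated chain carbon bound to an amide-type nitrogen and an aromatic carbon gives a 2.5-fold higher number from compound 2 to compound 3 (0.40 log units; beyond the scatter) and so moves the read-out toward more compound tolerated. This is the first single change shown here, and its step lies beyond the scatter. Compound 1 differs in more than one place and remains a limit of the assay: the limit of > 100 ug/mL in this assay, at which 1 of the 3 values shown sits.

As far as these compounds go, whether a methyl, a hydroxyl or an amine at this carbon would give a similar step remains open. So does the effect of changing the remaining phenyl.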